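Replacing 3-hydroxyphenyl with 6-aminopyridin-3-yl, without a starting number

The source may report more compounds than this note shows. Statements on the series, on what has been measured and on what is new or still open speak of the compounds shown alone.

In a functional assay on A2058 cells (Homo sapiens) for antiproliferative activity, read by luminescence and CellTiter-Glo, with a stated time of 96 h (a lower number here means a stronger inhibitor, a higher number a weaker inhibitor), compound 2 (`O=C(Nc1ccc(F)cc1)c1n[nH]cc1NC(=O)c1c(F)ccc(-c2cccc(O)c2)c1F`) has no usable number, and its entry reads "not determined" (no result reported). Its position therefore has to be judged from two close relatives that share the same core. Compound 1 (`NC(=O)c1ccc(-c2ccc(F)c(C(=O)Nc3c[nH]nc3C(=O)Nc3ccc(F)cc3)c2F)cn1`) gives 295 nM. Compound 3 (`O=C(Nc1ccc(F)cc1)c1n[nH]cc1NC(=O)c1c(F)ccc(-c2ccccc2)c1F`) gives 2370 nM.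

The change of interest leads from compound 2 to compound 4 (`Nc1ccc(-c2ccc(F)c(C(=O)Nc3c[nH]nc3C(=O)Nc3ccc(F)cc3)c2F)cn1`): 6-aminopyridin-3-yl in place of 3-hydroxyphenyl on an aromatic carbon. Put simply, 6-aminopyridin-3-yl takes the place of 3-hydroxyphenyl on an aromatic carbon, ortho to a fluoro group and para to a fluoro group.

Among the measured compounds shown here, only one measured step bears on this change: an 8.0-fold higher number from compound 1 to compound 3 (0.90 log units; beyond the scatter). There, phenyl replaces 6-carbamoylpyridin-3-yl, and the step lies beyond the scatter. With no number for compound 2, neither a size nor a direction can be given for the step to compound 4 in this assay. The group entering compound 4 is a pyridin-3-yl carrying a substituent at the 6 position, as in compound 1, which gives 295 nM. This single comparison is thin evidence, so the expected range is kept wide. For compound 4 the expected value is 400 nM, with an estimated range from 80 nM to 2000 nM.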

Compound 4, half-maximal inhibitory concentration: 8540 nM
Beside the measured number, compound 4's estimate is 21-fold (1.33 log units) below it; the whole stated range lies below it.
By their numbers in this assay, from the lowest: compound 1; then compound 3; then compound 4.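

In this assay there is a 3.6-fold higher number from compound 3 to compound 4 (0.56 log units; beyond the scatter), so a pyridine ring at this place does not by itself give a lower number than a plain phenyl ring, as the comparison with compound 1 alone might have suggested. The substituent on that pyridine ring matters a great deal: with amino in place of carbamoyl there is a 29-fold higher number from compound 1 to compound 4 (1.46 log units; beyond the scatter), and the phenyl of compound 3 falls between the two pyridine compounds, with one substituent on the stronger side of it and the other on the weaker side. Nothing measured here explains why the amino group does so much worse than the carbamoyl group.

Going by these compounds, compound 2 has no number, so the steps that start from it cannot be read, and the effect of moving from 3-hydroxyphenyl to 6-aminopyridin-3-yl remains unknown. Also open, on these data alone, is where an unsubstituted pyridin-3-yl would fall relative to compound 3, and whether a carboxylic acid or a methylamino group in place of the amino group would land nearer to compound 1 or to compound 4.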